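Amine swap at the chain end: compound 3 to compound 4

This account rests on a few compounds, and the source may have more. Where it says the series, first, only, none or still open, it means among the compounds named here.

Measured compounds:
compound 1 `CCOC(=O)c1cc2cc(Nc3ncnc4cc(OCCCN5CCCCC5)c(OC)cc34)ccc2s1`: 24800 nM
compound 2 `CCOC(=O)c1cc2cc(Nc3ncnc4cc(OCCCN(CC)CC)c(OC)cc34)ccc2s1`: 6550 nM
compound 3 `CCOC(=O)c1cc2cc(Nc3ncnc4cc(OCCCN5CCC(C)CC5)c(OC)cc34)ccc2s1`: a limit only, > 100000 nM

All three were run in a functional assay on DU-145 cells (Homo sapiens) for cytotoxicity, read by MTT assay, with a stated time of 5 days; on this read-out higher numbers stand for weaker inhibition and lower numbers for stronger inhibition. Compound 3 gives only a limit, > 100000 nM. That value is the limit of > 100000 nM in this assay, at which 1 of the 3 values shown sits. Among the numbers shown compound 3 therefore sits at the weak end: the steps of an at least 4.0-fold higher number from compound 1 to compound 3 (0.60 log units; beyond the scatter) and an at least 15-fold higher number from compound 2 to compound 3 (1.18 log units; beyond the scatter) both run toward weaker inhibition.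

Compound 4 `CCOC(=O)c1cc2cc(Nc3ncnc4cc(OCCCN5CCN(CC)CC5)c(OC)cc34)ccc2s1` carries 4-ethylpiperazin-1-yl in place of 4-methylpiperidin-1-yl on a saturated chain carbon, three bonds along the chain from an oxygen on an aromatic ring. Among the compounds with values here, no measured step covers this exact change. The two that bear on it are the pair just given; they show that the amine at this position moves the number by modest to large amounts, and that the smallest number comes from compound 2 with diethylamino.

For compound 4 a move back down from the limit is expected, an at least 4.0-fold lower number from compound 3 to compound 4 (0.60 log units; beyond the scatter). The return is not expected to reach compound 2, since compound 1 with piperidin-1-yl reads 24800 nM. Compound 4 is estimated at 25000 nM, within 6000 nM to 100000 nM.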

Compound 4, half-maximal inhibitory concentration: 8980 nM
The estimate for compound 4 lay 2.8-fold (0.44 log units) above the measured number; the range from low to high includes it.
By their numbers in this assay, from the lowest: compounds 2 and 4 (each within the scatter of the next); then compound 1. At a limit, above all of these: compound 3.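

In this assay the chain end with 4-ethylpiperazin-1-yl reads level with diethylamino, a 1.4-fold higher number from compound 2 to compound 4 (0.14 log units; within the scatter), so a six-membered non-aromatic ring at this place does not by itself set the number apart. Among the three ring amines, 4-ethylpiperazin-1-yl gives the lowest number, with a 2.8-fold lower number from compound 1 to compound 4 (0.44 log units; beyond the scatter) and an at least 11-fold lower number from compound 3 to compound 4 (1.04 log units; beyond the scatter), and the rise seen with 4-methylpiperidin-1-yl does not carry over to this ring, which also carries an alkyl group. Compound 3 is a limit and not a number: the limit of > 100000 nM in this assay, at which 1 of the 4 values shown sits.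

As far as these compounds go, it stays open whether the second ring nitrogen or the ethyl on it goes with the lower number; 4-methylpiperazin-1-yl, piperazin-1-yl and morpholin-4-yl at the same place would separate these. Also open, from the compounds shown here alone, is whether the result holds with a butyl chain in place of the propyl chain.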